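Alkyne substituent swap on the shared core: aryl variants

This account rests on a few compounds, and the source may have more. Where it says the series, first, only, none or still open, it means among the compounds named here.

Compound 1 `COC(=O)c1sc2cc(C#Cc3ccccn3)cnc2c1N` carries a pyridin-2-yl group on the triple-bonded carbon and, in a functional assay on NCI-H460 cells (Homo sapiens) for inhibition, read by sulforhodamine B assay, with a stated time of 48 h (a lower number here means a stronger inhibitor of growth, a higher number a weaker inhibitor of growth), compound 1 gives 34900 nM, the lowest of the two numbers recorded so far. Going by the values given here, its only neighbour is compound 2 `COC(=O)c1sc2cc(C#Cc3cccc(OC)c3)cnc2c1N`, for which compound 2 gives 49000 nM; the step of a 1.4-fold higher number from compound 1 to compound 2 (0.15 log units; within the scatter) shows that exchanging the pyridin-2-yl for 3-methoxyphenyl at this position moved the number no further than repeat measurements do.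

Compound 3 `COC(=O)c1sc2cc(C#Cc3ccccc3N)cnc2c1N` differs from compound 1 as follows: 2-aminophenyl in place of pyridin-2-yl on a triple-bonded carbon. Among the compounds with values here, the one measured step that bears on it is the same kind of change at the same place, from compound 1 to compound 2, and it stayed within the scatter. A comparable outcome is therefore expected, with no shift beyond the scatter in either direction: a 1.1-fold higher number from compound 1 to compound 3 (0.06 log units; within the scatter). Compound 3 is thus estimated at 40000 nM, with a range from 15000 nM to 110000 nM.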

Compound 3, concentration for 50% growth inhibition: 5700 nM
The estimate for compound 3 lay 7.0-fold (0.85 log units) above the measured number, outside the stated range (below it).
By their numbers in this assay, from the lowest: compound 3; then compounds 1 and 2 (each within the scatter of the next).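

The triple-bonded carbon is not indifferent to its aryl group in this assay: 2-aminophenyl gives a 6.1-fold lower number from compound 1 to compound 3 (0.79 log units; beyond the scatter) and an 8.6-fold lower number from compound 2 to compound 3 (0.93 log units; beyond the scatter), whereas the step between the other two groups stayed within the scatter. Of the differences counted between the groups leaving and entering, 2-aminophenyl carries 1 hydrogen-bond donor where pyridin-2-yl has 0, and its ring is of carbon only, but these three compounds cannot separate the two differences. Nothing available bears on why the number fell.

A plain phenyl, a 3-aminophenyl or a 2-hydroxyphenyl group at this place would show whether the drop follows the amine, its place on the ring or the donor alone. Also open, from the compounds shown here alone, is whether the step would persist with a carboxylic acid or an amide in place of the ester on the shared core.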